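From compound 1 to compound 3: replacing the methoxy group

A few compounds are considered here, and "the series" means these few. Any claim that something is new, unique, unknown or untested is made for them only; others in the source may bear on it.

In a functional assay on HepG2 cells (Homo sapiens) for antiproliferative activity, read by MTT assay, with a stated time of 48 h (a higher number here means a weaker inhibitor, a lower number a stronger inhibitor), compound 1 (`COc1ccc(N(C)c2cc(C)nc(C)n2)cc1`) gives 824 nM. For the measured compounds named here, compound 2 (`COc1ccc(N(C)c2cc(C)nc(C)n2)cc1Cl`) gives 787 nM, so compound 1 stands level with the only other measured compound, within the scatter. Compound 3 (`Cc1cc(N(C)c2ccc([Se]C#N)cc2)nc(C)n1`) has not yet been measured. The change is a group of 3 heavy atoms (1 carbon, 1 nitrogen, 1 selenium; no ring) in place of a group of 2 heavy atoms (1 carbon, 1 oxygen; no ring), on an aromatic carbon: on an aromatic carbon, para to a large group, a group of 3 heavy atoms takes the place of the methoxy. Going by the values given here, the one measured step, a 1.0-fold lower number from compound 1 to compound 2 (0.02 log units; within the scatter), lies within the scatter. Among the compounds with values here, it leaves the methoxy in place, so no measured step tests this replacement, and no direction can be drawn from it. The expected step in this assay is therefore none beyond the scatter, held only loosely: a 1.2-fold lower number from compound 1 to compound 3 (0.07 log units; within the scatter). For compound 3 the estimated value is 700 nM, with an expected range of 120 nM to 4000 nM.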

Compound 3, half-maximal inhibitory concentration: 155 nM
The estimate for compound 3 lay 4.5-fold (0.65 log units) above the measured number, within the range that was stated.
By their numbers in this assay, from the lowest: compound 3; then compounds 2 and 1 (each within the scatter of the next).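

This position responds to substitution: in this assay, the methoxy para to a large group gives way to the group of 3 heavy atoms (1 carbon, 1 nitrogen, 1 selenium), with a 5.3-fold lower number from compound 1 to compound 3 (0.73 log units; beyond the scatter). For the compounds shown here, the earlier step, a 1.0-fold lower number from compound 1 to compound 2 (0.02 log units; within the scatter), left the methoxy in place and showed no such movement, so this is the first step beyond the scatter, though it rests on a single pair. The hydrogen-bond counts printed for the two groups are the same, and nothing available bears on why the number moves.

The compounds shown leave open which part of the entering group carries the step, since a nitrile or a thiocyanate on this aromatic carbon would separate selenium from the triple bond. Also open, from the compounds shown here alone, is whether the step holds with the chloro of compound 2 present.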